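This account rests on a few compounds, and the source may have more. Where it says the series, first, only, none or still open, it means among the compounds named here.

Compound 1 `Cc1cc(NC(=O)Nc2ccc(O)cc2)c2ccccc2n1` holds the lowest of the two numbers measured in a physicochemical assay for solubility, at pH 7.4; on this read-out higher numbers stand for higher solubility and lower numbers for lower solubility: compound 1 gives 100 nM, while compound 2 `Cc1cc(NC(=O)Nc2ccccc2N)c2ccccc2n1` gives 51800 nM. Within the data shown here, the only measured step, a 520-fold higher number from compound 1 to compound 2 (2.71 log units; beyond the scatter), is large. Compound 3 `Cc1cc(NC(=O)Nc2ccc(C(F)(F)F)cc2)c2ccccc2n1` differs from compound 1 by trifluoromethyl in place of hydroxy on an aromatic carbon. That single measured step concerns a different replacement, so it offers little guidance here, and the expectation rests on the value of compound 1 alone. Compound 3 is therefore expected to show a small downward shift at most, a 1.7-fold lower number from compound 1 to compound 3 (0.22 log units; within the scatter), with an estimate of 60 nM and a range from 10 nM to 400 nM.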

Compound 3, solubility: 100 nM
Compound 3: the middle estimate sits 1.7-fold (0.22 log units) below what was measured, within the range that was stated.
By their numbers in this assay, from the lowest: compounds 1 and 3 (each within the scatter of the next); then compound 2.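

In this assay, trifluoromethyl in place of hydroxy on this aromatic carbon, para to a large group, gives no change at the digits printed from compound 1 to compound 3 (within the scatter). At this position, then, a group with 0 hydrogen-bond donors and 0 hydrogen-bond acceptors gives the same printed number as one with 1 of each, which the earlier pair could not show. No evidence is at hand on why the number stays the same. The compounds shown leave open whether an amine or a carboxylic acid on this same carbon would shift the number, and whether the amino group or its place on the ring accounts for a 520-fold higher number from compound 1 to compound 2 (2.71 log units; beyond the scatter).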